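The compounds below may be only part of what the source reports. "The series", "measured", "known", "first", "only" and "open" are said of these compounds alone.

Measured compounds in a functional assay on SK-N-SH cells (Homo sapiens) for cytotoxicity, read by MTT assay, with a stated time of 48 h; on this read-out higher numbers stand for weaker inhibition and lower numbers for stronger inhibition:
compound 1, `O=C1Nc2ccccc2C1(c1c[nH]c2ccccc12)c1c[nH]c2ccccc12`, gives 11300 nM
compound 2, `COc1cccc2[nH]cc(C3(c4c[nH]c5cccc(OC)c45)C(=O)Nc4ccccc43)c12`, gives 4700 nM
compound 3, `O=C1Nc2ccc(F)cc2C1(c1c[nH]c2ccccc12)c1c[nH]c2ccccc12`, gives 67300 nM

Compound 2 shows the lowest of the three numbers; the difference between its core and the core of compound 1 is not broken down here. Compound 3 arises from compound 1 by fluoro in place of hydrogen on an aromatic carbon, and in this assay this change gives a 6.0-fold higher number from compound 1 to compound 3 (0.77 log units; beyond the scatter). Compound 4, `COc1cccc2[nH]cc(C3(c4c[nH]c5cccc(OC)c45)C(=O)Nc4ccc(F)cc43)c12`, is not yet measured; it arises from compound 2 by fluoro in place of hydrogen on an aromatic carbon, the same change at the same place, so the change occurs twice in the set, once measured and once open. In this assay the step from compound 2 to compound 4 is expected to be a 5.3-fold higher number from compound 2 to compound 4 (0.73 log units; beyond the scatter), set beside the earlier step of a 6.0-fold higher number from compound 1 to compound 3 (0.77 log units; beyond the scatter), because it rests on that single observed step a 6.0-fold higher number from compound 1 to compound 3 (0.77 log units; beyond the scatter) made on a different core, so the range is kept wide. Compound 4 is thus estimated at 25000 nM in this assay, with an expected range from 8000 nM to 80000 nM.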

Compound 4, half-maximal inhibitory concentration: 12100 nM
The estimate for compound 4 lay 2.1-fold (0.32 log units) above the measured number; the measured number falls inside the stated range.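

In this assay fluoro in place of hydrogen on an aromatic carbon gives a 2.6-fold higher number from compound 2 to compound 4 (0.41 log units; beyond the scatter) and so weakens inhibition on this core as well. The two steps point the same way, and their sizes cannot be told apart: the same change on two cores in this assay, a 6.0-fold higher number (0.77 log units; beyond the scatter) from compound 1 to compound 3 and a 2.6-fold higher number (0.41 log units; beyond the scatter) from compound 2 to compound 4, 2.3-fold (0.36 log units) apart, within the scatter of two such steps. Going by these compounds alone, this supports carrying the change between these two cores as a loss of inhibition of similar size, but it rests on only two pairs with a single group at a single place, and it shows nothing about other cores, other cell lines or why the number rises.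

The compounds shown leave open whether another group on the same aromatic carbon, such as chloro, a nitrile or an amine, would also raise the number or would lower it instead. They also leave open what a methyl or a longer chain in place of the amide hydrogen would do on either core.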